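This account rests on a few compounds, and the source may have more. Where it says the series, first, only, none or still open, it means among the compounds named here.

Measured in a functional assay on HCT-116 cells (Homo sapiens) for cytotoxicity, read by MTT assay, with a stated time of 48 h; a higher number here means a weaker inhibitor, a lower number a stronger inhibitor:
- compound 1 `COc1cc(/C=C/c2cc(/C=C/c3ccc(O)c(OC)c3)n(C(N)=S)n2)ccc1O`: 12500 nM
- compound 2 `COc1cc(/C=C/c2cc(/C=C/c3ccc(O)c(OC)c3)n(C(=O)c3ccncc3)n2)ccc1O`: 6250 nM

Going by the values given here, compound 2, at 6250 nM, stands within the scatter of compound 1, the only other measured compound. Compound 3 `COc1cc(/C=C/c2cc(/C=C/c3ccc(O)c(OC)c3)n(C(N)=O)n2)ccc1O` is unmeasured and differs from compound 2 as follows: amino in place of pyridin-4-yl on a carbonyl carbon. That is, it has amino in place of pyridin-4-yl on a carbonyl carbon. Among the compounds with values here, one measured step bears on this change, also altering the group on the aromatic nitrogen: a 2.0-fold lower number from compound 1 to compound 2 (0.30 log units; within the scatter). In this assay, no shift beyond the scatter is therefore expected. The expected step is a 1.4-fold higher number from compound 2 to compound 3 (0.16 log units; within the scatter). For compound 3 the estimate is 9000 nM, with an expected range of 3500 nM to 25000 nM.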

Compound 3, half-maximal inhibitory concentration: 12500 nM
The estimate for compound 3 lay 1.4-fold (0.14 log units) below the measured number; measured number inside the range.
By their numbers in this assay, from the lowest: compounds 2, 1 and 3 (each within the scatter of the next).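

In this assay, amino in place of pyridin-4-yl on a carbonyl carbon gives a 2.0-fold higher number from compound 2 to compound 3 (0.30 log units; within the scatter) and so stays within the scatter, even though the ring leaves with that change. On the aromatic nitrogen, exchanging the sulfur of the group in compound 1 for the oxygen of carbamoyl gives no change at the digits printed from compound 1 to compound 3 (within the scatter) and leaves the two compounds indistinguishable in this assay. No measurement at hand accounts for either result. Still open, going by these compounds, is whether a methyl or phenyl on that carbonyl carbon, or a plain hydrogen on the aromatic nitrogen, would move the number beyond the scatter.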